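Taking away a fluoro group on two related cores

This account rests on a few compounds, and the source may have more. Where it says the series, first, only, none or still open, it means among the compounds named here.

Compound 1 `COc1ccc(NS(=O)(=O)c2cc(F)c(F)c(F)c2F)cc1` gives 400 nM in a functional assay on NCI/ADR-RES cells (Homo sapiens) for cytotoxicity; on this read-out lower numbers stand for stronger inhibition of growth and higher numbers for weaker inhibition of growth. Compound 3 `COc1ccc(NS(=O)(=O)c2cc(F)c(F)c(F)c2)cc1` gives 3400 nM in this assay; the change hydrogen in place of fluoro on an aromatic carbon made an 8.5-fold higher number from compound 1 to compound 3 (0.93 log units; beyond the scatter). Compound 2 `COc1ccc(NS(=O)(=O)c2c(F)cc(F)c(F)c2F)cc1` gives 4500 nM in this assay; how its core differs from that of compound 1 is not broken down here. Compound 2 and compound 3 lie within the scatter of each other, while compound 1 stands well apart from compound 2. Compound 4 `COc1ccc(NS(=O)(=O)c2c(F)cc(F)cc2F)cc1` is not yet measured and differs from compound 2 by hydrogen in place of fluoro on an aromatic carbon. This is the same kind of change as from compound 1 to compound 3, but the place differs: ortho to two fluoro groups, meta to a large group and para to a fluoro group, rather than ortho to a fluoro group, ortho to a large group, meta to a fluoro group and para to a fluoro group. For compound 4 a step of a 2.7-fold higher number from compound 2 to compound 4 (0.43 log units; beyond the scatter) is expected in this assay, resting on an 8.5-fold higher number from compound 1 to compound 3 (0.93 log units; beyond the scatter) and tempered for the different surroundings. The estimate for compound 4 is 12000 nM, expected to fall between 4000 nM and 40000 nM.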

Compound 4, concentration for 50% growth inhibition: > 50000 nM
Compound 4 gave a limit, no number; the forecaster's own chance of this, stated with the estimate: 10%; at least 4.1-fold (0.61 log units) between middle value and limit.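

In this assay compound 4 gives > 50000 nM, which is a limit of the assay and not a number. Hydrogen in place of fluoro gave an at least 11-fold higher number from compound 2 to compound 4 (1.04 log units; beyond the scatter), so on both cores the change moved the read-out the same way, towards weaker inhibition of growth: the same change on two cores in this assay, an 8.5-fold higher number (0.93 log units; beyond the scatter) from compound 1 to compound 3 and an at least 11-fold higher number (1.04 log units; beyond the scatter) from compound 2 to compound 4; the limit leaves it open whether they differ Two cores show that the direction carried over here, but they do not show that the size of the step carries over, nor do they make a rule for the series.

The compounds shown leave open what a chloro group or an amine would do in place of the fluoro group. They also leave open whether the change would behave the same way with a longer chain in place of the methoxy group.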